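The source may report more compounds than this note shows. Statements on the series, on what has been measured and on what is new or still open speak of the compounds shown alone.

Measured compounds in an ADME assay on HepG2 2.2.15 cells (Homo sapiens) for cytotoxicity; on this read-out higher numbers stand for lower toxicity in this test and lower numbers for higher toxicity in this test:
- compound 1 `CC(=O)OCC(=O)OCCc1c(-c2ccccc2Cl)c2cc(Cl)ccc2[nH]c1=O`: 100000 nM
- compound 2 `CC12CCC(C(=O)OCCc3c(-c4ccccc4Cl)c4cc(Cl)ccc4[nH]c3=O)(OC1=O)C2(C)C`: > 1800000 nM

For compound 2 the value in this assay is a limit of the test, not a number, as the entry the limit of > 1800000 nM in this assay, at which 1 of the 2 values shown sits, records. Compound 1 gives a number in this assay of 100000 nM. Among the measured compounds shown here, the one measured step, an at least 18-fold higher number from compound 1 to compound 2 (1.25 log units; beyond the scatter), runs toward the limit and is large.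

Compound 3 `O=C(OCCc1c(-c2ccccc2Cl)c2cc(Cl)ccc2[nH]c1=O)c1ccco1` differs from compound 2 by a group of 5 heavy atoms (4 carbon, 1 oxygen; one five-membered aromatic ring with 1 hetero atom) in place of a group of 11 heavy atoms (9 carbon, 2 oxygen; one five-membered non-aromatic ring of carbon only, one five-membered non-aromatic ring with 1 hetero atom), on a carbonyl carbon. This change runs in the opposite direction, in counted size, to the step from compound 1 to compound 2, and the same ester carbonyl carbon is the place of change in both. It is therefore expected that the number in this assay moves back toward that of compound 1, a step estimated at an at least 5.1-fold lower number from compound 2 to compound 3 (0.71 log units; beyond the scatter), though it is uncertain in size since compound 2 is only a limit. Compound 3 is estimated at 350000 nM, with a range of 90000 nM to 1800000 nM.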

Compound 3, half-maximal cytotoxic concentration: 98000 nM
Compound 3: middle estimate off by 3.6-fold (0.55 log units), on the high side; the measured number falls inside the stated range.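

At the ester carbonyl carbon, furan-2-yl and acetoxymethyl are not told apart in this assay: a 1.0-fold lower number from compound 1 to compound 3 (0.01 log units; within the scatter). The other step, an at least 18-fold lower number from compound 2 to compound 3 (1.26 log units; beyond the scatter), shows that the large gap is not tied to one smaller group, as the group of 11 heavy atoms, with its two five-membered non-aromatic rings, stands apart from both smaller groups. Compound 2 is recorded as a limit, not a number: the limit of > 1800000 nM in this assay, at which 1 of the 3 values shown sits.

Still open, as far as these compounds go, is whether the count of heavy atoms or the pair of non-aromatic rings separates compound 2 from compound 1 and compound 3. Also open, from the compounds shown here alone, is how a single non-aromatic ring such as cyclohexyl, or an amine such as dimethylaminomethyl, on the same carbonyl carbon would read in this assay.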